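This account rests on a few compounds, and the source may have more. Where it says the series, first, only, none or still open, it means among the compounds named here.

Compound 1 `COc1ccccc1C#Cc1ccccc1C#CCCCCO`: in a functional assay on LOX IMVI cells (Homo sapiens) for cytotoxicity (a lower number here means a stronger inhibitor of growth, a higher number a weaker inhibitor of growth), compound 1 gives 17900 nM.
Compound 2 `OCCCCC#Cc1ccccc1C#Cc1ccccn1`: in this assay compound 2 gives 27700 nM.
Compound 3 `OCCCCC#Cc1ccccc1C#Cc1ccccc1C(F)(F)F`: in this assay compound 3 gives 4900 nM.

Compound 2 has the highest of these three numbers; compound 1 lies within the usual scatter of it, while compound 3 lies clearly lower. Compound 4 `OCCCCC#Cc1ccccc1C#Cc1ccc(O)cc1` differs from compound 2 in one place: 4-hydroxyphenyl in place of pyridin-2-yl on a triple-bonded carbon. For the measured compounds named here, the only measured one-change step, a 3.7-fold lower number from compound 1 to compound 3 (0.56 log units; beyond the scatter), exchanges one substituent on a carbon-only ring for another and leaves the ring itself untouched, so it does not speak directly to trading a pyridin-2-yl for a 4-hydroxyphenyl. Going by the values given here, what the three values do show is that the one compound clearly apart from compound 2, compound 3, carries a carbon-only ring at this position, and compound 1, also with a carbon-only ring there, is not above compound 2. The step of a 1.8-fold lower number from compound 2 to compound 4 (0.27 log units; within the scatter) is therefore expected to be small, toward a lower number, and may not clear the scatter. Compound 4 is estimated at 15000 nM, within a range from 5000 nM to 40000 nM.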

Compound 4, concentration for 50% growth inhibition: 13600 nM
The estimate for compound 4 lay 1.1-fold (0.04 log units) above the measured number; low and high end bracket the measured number.
By their numbers in this assay, from the lowest: compound 3; then compounds 4, 1 and 2 (each within the scatter of the next, the first and the last beyond it).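

In this assay, for the compounds shown here, the step is a 2.0-fold lower number from compound 2 to compound 4 (0.31 log units; beyond the scatter) and this is the first measured change of the ring itself on this triple-bonded carbon, rather than of a substituent on that ring. It moves the number modestly, only just past the scatter. The change is also a double one: the ring nitrogen of pyridin-2-yl leaves and a hydroxyl arrives on a carbon-only ring, and this single step cannot separate the two. No measurement here accounts for the shift.

The compounds shown leave open how a plain phenyl ring without the hydroxyl would compare with compound 2 and compound 4, a comparison that would split the two parts of the change. They also leave open whether an amine or a carboxylic acid in place of that hydroxyl would give a lower or a higher number.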